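Two Aryl Amide Analogues of a Shared Core, Weak Inhibition

The source may hold more compounds than are shown below. What is called first, only, known or untested is meant among the compounds shown, and "the series" means these compounds.

Measured compounds:
compound 1, `CCOC(=O)C1=Cc2ccccc2OC1(OCc1cn(CC(=O)Nc2ccc(C)cc2)nn1)C(F)(F)F`, > 150000 nM
compound 2, `CCOC(=O)C1=Cc2ccccc2OC1(OCc1cc(-c2ccc(Br)cc2)no1)C(F)(F)F`, 71700 nM

The two measured compounds share a core and differ in the group attached to it. In a functional assay on DU-145 cells (Homo sapiens) for inhibition, read by MTT assay, with a stated time of 24 h (a lower number here means a stronger inhibitor, a higher number a weaker inhibitor), compound 1 gives only a limit, > 150000 nM, so no number is known for it. Compound 2 gives 71700 nM in this assay, a weak result. Compound 1 thus stands at the limit of this assay, as the limit of > 150000 nM in this assay, at which 1 of the 2 values shown sits, records, and it cannot be placed against compound 2 beyond that.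

Compound 3, `CCOC(=O)C1=Cc2ccccc2OC1(OCc1cn(CC(=O)Nc2cccc(F)c2)nn1)C(F)(F)F`, has not yet been measured in this assay. It differs from compound 1 in one place: 3-fluorophenyl in place of 4-methylphenyl on an amide-type nitrogen. For the measured compounds named here, because compound 1 gives only the limit > 150000 nM, the step from it to compound 3 cannot be sized from the data, and no step within or beyond the scatter can be ruled out. A small change in the aryl amide is expected to leave compound 3 near the limit, with a number no higher from compound 1 to compound 3 (the limit leaves the size open) as the expected step. Compound 3 is estimated at 150000 nM in this assay, in the range 50000 nM to 400000 nM.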

Compound 3, half-maximal inhibitory concentration: > 150000 nM
Compound 3 gave a limit, no number (the forecaster's own chance of this, stated with the estimate: 60%); the middle value lies on the limit itself.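

In this assay compound 3 gives > 150000 nM as a limit, not a number. For the compounds shown here, compound 1 also gives a limit, so no step from compound 1 to compound 3 can be read: the limit of > 150000 nM in this assay, at which 2 of the 3 values shown sit. The compounds shown leave open whether 3-fluorophenyl in place of 4-methylphenyl on an amide-type nitrogen changes inhibition at all.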